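The source may report more compounds than this note shows. Statements on the series, on what has been measured and on what is new or still open speak of the compounds shown alone.

In an assay on isolated protein for binding affinity to adenosine receptor A1 (Bos taurus) (on this read-out lower numbers stand for stronger inhibition and higher numbers for weaker inhibition), compound 1 `COc1ccc(C(=O)Nc2nc(-c3ccccc3)nc3c2nnn3Cc2ccccc2F)cc1` gives 21900000 nM, the second highest of the three numbers recorded. Compound 3 `CNc1nc(-c2ccccc2)nc2c1nnn2Cc1ccccc1Cl` gives 191000000 nM in this assay, a higher number beyond the scatter, while compound 2 `FC(F)(F)c1ccccc1Cn1nnc2c(NC3CCCC3)nc(-c3ccccc3)nc21` gives 600000 nM, a lower number also beyond the scatter. Compound 4 `CCCCCCNc1nc(-c2ccccc2)nc2c1nnn2Cc1ccccc1F` has not been measured; it differs from compound 1 by hexyl in place of (4-methoxyphenyl)carbonyl on a nitrogen on an aromatic ring. For the measured compounds named here, no step between measured compounds isolates this change. Since compound 2, which carries a cyclopentyl on that nitrogen, gives 600000 nM, the expected step from compound 1 to compound 4 is toward a lower number, beyond the scatter, an 11-fold lower number from compound 1 to compound 4 (1.04 log units; beyond the scatter). Compound 4 is therefore estimated at 2000000 nM, with a range from 300000 nM to 15000000 nM.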

Compound 4, inhibition constant: 25000000 nM
Estimate against measurement, compound 4: 13-fold (1.10 log units) below; measured number outside the range, above it.
By their numbers in this assay, from the lowest: compound 2; then compounds 1 and 4 (each within the scatter of the next); then compound 3.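

In this assay, for the compounds shown here, hexyl in place of (4-methoxyphenyl)carbonyl on this nitrogen gives a 1.1-fold higher number from compound 1 to compound 4 (0.06 log units; within the scatter), so the first step at this position shows no change beyond the scatter. Losing the aromatic ring, the carbonyl and both hydrogen-bond acceptors of the leaving group therefore leaves the number where it was, and both compounds stay at the weak end of the series. Nothing measured here accounts for this. What the compounds shown leave open is how a butyl chain, a benzyl group or a chain ending in an amine would read on this nitrogen.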